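This account rests on a few compounds, and the source may have more. Where it says the series, first, only, none or still open, it means among the compounds named here.

Working notes on the series. In a functional assay on L1210 (1565) cells (Mus musculus) for cytotoxicity (a lower number here means that less compound is needed, a higher number that more compound is needed for the effect), compound 1 `Oc1ccc2nc(-c3ccccc3)cc(O)c2c1` gives 0.83 ug/mL, the higher of the two numbers available. The nearest value belongs to compound 3 `Oc1cc(-c2ccccc2)nc2cc(F)ccc12`, at 0.16 ug/mL, a lower number by a margin beyond the scatter. Compound 2 `CCCOc1cc(-c2ccccc2)nc2ccccc12` reads > 10 ug/mL, which is a limit of the assay and not a number.

The next compound is compound 4 `COc1ccc2nc(-c3ccccc3)cc(O)c2c1`, reached from compound 1 by one change: methyl in place of hydrogen on an oxygen on an aromatic ring. In words, this is methyl in place of hydrogen on an oxygen on an aromatic ring, or hydroxy to methoxy.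

For the measured compounds named here, no pair of measured compounds shows this change on its own, so its size in this assay has not been observed. Going by the values given here, the only hint is that compound 2, the sole measured ether, gives > 10 ug/mL. That is a single compound, so the expectation stays loose: a move towards a higher number, probably beyond the scatter, with no change beyond the scatter still possible. The expected size is a 3.0-fold higher number from compound 1 to compound 4 (0.48 log units; beyond the scatter). For compound 4 the estimated value is 2.5 ug/mL, with an expected range from 0.5 ug/mL to 10 ug/mL.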

Compound 4, half-maximal effective concentration: 0.06 ug/mL
The estimate for compound 4 lay 42-fold (1.62 log units) above the measured number, outside the stated range (below it).
By their numbers in this assay, from the lowest: compound 4; then compound 3; then compound 1. At a limit, above all of these: compound 2.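

For the compounds shown here, the oxygen on the aromatic ring of compound 1 carries a methyl without loss of effect: in this assay, hydroxy to methoxy gives a 14-fold lower number from compound 1 to compound 4 (1.14 log units; beyond the scatter), a large step and the only direct reading of this change. The hydrogen on this oxygen is therefore not required for the effect in this assay, and less compound is needed once methyl takes its place. Compound 2 remains a limit of the assay and not a number, and it differs from compound 4 in more than one place, so it sets no size for this change: the limit of > 10 ug/mL in this assay, at which 1 of the 4 values shown sits.

From the compounds shown here alone, whether an ethyl group or a longer chain on this oxygen, or an amine in place of the methoxy, keeps the lower number stays open, as does whether methyl on the other hydroxy of the core gives a step of similar size. The step rests on a single pair, and the compounds shown give no reason for its size.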